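The compounds below may be only part of what the source reports. "The series", "measured", "known", "first", "only" and "open" are said of these compounds alone.

In a functional assay on A-375 cells (Homo sapiens) for antiproliferative activity, read by MTT assay, with a stated time of 72 h (on this read-out higher numbers stand for weaker inhibition and lower numbers for stronger inhibition), compound 1 `COc1ncc(-c2ccc3c(c2)NC(=O)CO3)cc1NS(=O)(=O)c1ccc(F)cc1` gives 26300 nM and compound 3 `COc1ncc(-c2ccc3c(c2)N(c2ccccc2)C(=O)CO3)cc1NS(=O)(=O)c1ccc(F)cc1` gives 15200 nM, two values within the scatter of each other, as a 1.7-fold lower number from compound 1 to compound 3 (0.24 log units; within the scatter) shows. Compound 2 `COc1cccc(N2C(=O)COc3ccc(-c4cnc(OC)c(NS(=O)(=O)c5ccc(F)cc5)c4)cc32)c1` reports only a limit of the assay, > 40000 nM. Compound 4 `COc1ncc(-c2ccc3c(c2)N(c2ccc(Cl)cc2)C(=O)CO3)cc1NS(=O)(=O)c1ccc(F)cc1` differs from compound 3 by chloro in place of hydrogen on an aromatic carbon, turning phenyl into 4-chlorophenyl. Among the measured compounds shown here, the nearest evidence is the one measured step involving a substituent on that phenyl, an at least 2.6-fold lower number from compound 2 to compound 3 (0.42 log units; beyond the scatter), though it concerns methoxy rather than chloro. In this assay, little change is therefore expected, with any drift towards higher numbers. The expected step is a 1.1-fold higher number from compound 3 to compound 4 (0.02 log units; within the scatter), which is none beyond the scatter. For compound 4 the estimated value is 16000 nM, within an expected range of 6000 nM to 40000 nM.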

Compound 4, half-maximal inhibitory concentration: 24100 nM
Beside the measured number, compound 4's estimate is 1.5-fold (0.18 log units) below it; low and high end bracket the measured number.
By their numbers in this assay, from the lowest: compounds 3, 4 and 1 (each within the scatter of the next). At a limit, above all of these: compound 2.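

In this assay, chloro in place of hydrogen para to a large group shifts the number only within the scatter, a 1.6-fold higher number from compound 3 to compound 4 (0.20 log units; within the scatter), so the 4-chlorophenyl group gives no clear change from phenyl. Nor does it separate from the hydrogen on the amide-type nitrogen, a 1.1-fold lower number from compound 1 to compound 4 (0.04 log units; within the scatter). Against the 3-methoxyphenyl group only a floor can be read, an at least 1.6-fold lower number from compound 2 to compound 4 (0.22 log units; that floor lies within the scatter), and that floor rests on a limit: the limit of > 40000 nM in this assay, at which 1 of the 4 values shown sits.

The compounds shown leave open whether an amine or a carboxylic acid at this position would move the number beyond the scatter.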